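The source may report more compounds than this note shows. Statements on the series, on what has been measured and on what is new or still open speak of the compounds shown alone.

Within the data shown here, compound 3 `O=S(=O)(c1ccc(F)c(F)c1)c1cnc2c(F)cccc2c1-c1ccc(F)cc1` gives 0.78 mL/min in an ADME assay on microsomes from liver (Homo sapiens) for metabolic stability, tested at 2.5 uM (a higher number here means faster removal of the compound, a lower number slower removal), the highest of the three numbers measured so far. Compound 1 `O=S(=O)(c1ccc(F)c(F)c1)c1cnc2c(F)cccc2c1-c1ccc(Cl)cc1` gives 0.28 mL/min, the nearest value, and compound 2 `O=S(=O)(c1cccc(F)c1)c1cnc2c(F)cccc2c1-c1ccccc1F` gives the furthest. Among the measured compounds shown here, the only single-point step recorded is a 2.8-fold higher number from compound 1 to compound 3 (0.44 log units; beyond the scatter). Compound 4 `O=S(=O)(c1ccc(F)c(F)c1)c1cnc2c(F)cccc2c1-c1ccccc1F` differs from compound 3 in one place: 2-fluorophenyl in place of 4-fluorophenyl on an aromatic carbon. For the measured compounds named here, no measured step covers this change. Compound 2 also carries a 2-fluorophenyl and gives 0.21 mL/min, but it differs from compound 4 in a second place too, so it only hints at a direction. A step within the scatter, leaning lower, is therefore expected, as a 2.0-fold lower number from compound 3 to compound 4 (0.29 log units; within the scatter). Compound 4 is estimated at 0.4 mL/min, with a range from 0.2 mL/min to 0.8 mL/min.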

Compound 4, intrinsic clearance in a liver preparation (reported as CLH), per the amount of preparation that the assay uses: 1.39 mL/min
Compound 4: the middle estimate sits 3.5-fold (0.54 log units) below what was measured; the whole stated range lies below it.
By their numbers in this assay, from the lowest: compounds 2 and 1 (each within the scatter of the next); then compounds 3 and 4 (each within the scatter of the next).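

Placing 2-fluorophenyl in place of 4-fluorophenyl on this aromatic carbon gives a 1.8-fold higher number from compound 3 to compound 4 (0.25 log units; within the scatter) and so leaves the two fluorine placements unresolved. By contrast, 2-fluorophenyl in place of 4-chlorophenyl gives a 5.0-fold higher number from compound 1 to compound 4 (0.70 log units; beyond the scatter) and clearly separates those two compounds. A single fluoro in place of hydrogen gives a 6.6-fold higher number from compound 2 to compound 4 (0.82 log units; beyond the scatter) even with 2-fluorophenyl present in both compounds, so that group alone does not keep the number low. No available evidence explains these steps. Going by these compounds, it also remains open how an amine or a carboxylic acid on this phenyl ring would behave.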